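This account rests on a few compounds, and the source may have more. Where it says the series, first, only, none or still open, it means among the compounds named here.

Of the compounds shown here, two have been measured in an assay on membranes from uterus (Sus scrofa) for displacement of a labelled ligand from Type-2 angiotensin II receptor (Homo sapiens); a lower number here means a stronger inhibitor, a higher number a weaker inhibitor. Compound 1 `COCCOC(=O)NS(=O)(=O)c1sc(CC(C)C)cc1-c1ccc(Cn2ccnc2)cc1` gives 31 nM there, and compound 2 `CC(C)Cc1cc(-c2ccc(Cn3ccnc3)cc2)c(S(=O)(=O)NC(=O)OC(C)(C)C)s1` gives 63 nM, so compound 2 stands with the higher of the two numbers. For the measured compounds named here, the only measured step, a 2.0-fold higher number from compound 1 to compound 2 (0.31 log units; beyond the scatter), is a modest one.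

Compound 3 `CCCCS(=O)(=O)NS(=O)(=O)c1sc(CC(C)C)cc1-c1ccc(Cn2ccnc2)cc1` has not yet been measured. It differs from compound 2 in one place: butylsulfonyl in place of tert-butoxycarbonyl on a sulfonamide nitrogen. Going by the values given here, this is a different kind of change from the one between compound 1 and compound 2, which only swapped the group on the oxygen of the carbonyl; here the carbonyl and its oxygen leave altogether and a second sulfonyl enters on the nitrogen. Among the compounds with values here, no measured step bears directly on such a change, so no direction can be read from the data, and a step of any modest size in either direction seems possible.

On that basis compound 3 is expected to give about 60 nM in this assay, somewhere between 15 nM and 250 nM, meaning an expected step of a 1.1-fold lower number from compound 2 to compound 3 (0.02 log units; within the scatter).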

Compound 3, inhibition constant: 76 nM
Compound 3: the middle estimate sits 1.3-fold (0.10 log units) below what was measured, within the range that was stated.
By their numbers in this assay, from the lowest: compound 1; then compounds 2 and 3 (each within the scatter of the next).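

Swapping tert-butoxycarbonyl for butylsulfonyl on the sulfonamide nitrogen gives a 1.2-fold higher number from compound 2 to compound 3 (0.08 log units; within the scatter) in this assay. A carbonyl is therefore not needed on this nitrogen for a value in this range, since a second sulfonyl serves about as well in compound 3 as the carbamate group does in compound 2. Measured against the (2-methoxyethoxy)carbonyl group, butylsulfonyl gives a 2.5-fold higher number from compound 1 to compound 3 (0.39 log units; beyond the scatter), so compound 1 keeps the lowest number of the three, and nothing available explains these numbers.

The compounds shown leave open what a shorter or longer chain on the sulfonyl would do, or a phenyl ring in place of the butyl chain. They also leave open how a 2-methoxyethyl chain on the sulfonyl would compare with the butyl chain.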